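A few compounds are considered here, and "the series" means these few. Any claim that something is new, unique, unknown or untested is made for them only; others in the source may bear on it.

Working notes on the series. Compound 3 `COc1ccc(Nc2nc(SCc3ccc(C(F)(F)F)cc3)nc3ccccc23)c(OC)c1` is recorded in a functional assay on HGC-27 cells (Homo sapiens) for cytotoxicity, read by MTT assay, with a stated time of 72 h (a higher number here means a weaker inhibitor, a lower number a stronger inhibitor), only as a limit of the assay, > 50000 nM. Compound 1 `O=[N+]([O-])c1cccc(Nc2nc(SCc3ccc(C(F)(F)F)cc3)nc3ccccc23)c1` also stands at a limit in this assay, > 50000 nM. Compound 2 `FC(F)(F)c1ccc(CSc2nc(Nc3ccc(Cl)cc3)c3ccccc3n2)cc1` gives a number in this assay, 14100 nM. The readable steps are an at least 3.5-fold lower number from compound 1 to compound 2 (0.54 log units; beyond the scatter) and an at least 3.5-fold higher number from compound 2 to compound 3 (0.54 log units; beyond the scatter); the step that the two limits leave unreadable from compound 1 to compound 3 cannot be sized because of the limit of > 50000 nM in this assay, at which 2 of the 3 values shown sit. Compound 4 `COc1cc(Nc2nc(SCc3ccc(C(F)(F)F)cc3)nc3ccccc23)cc(OC)c1` differs from compound 3 by 3,5-dimethoxyphenyl in place of 2,4-dimethoxyphenyl on a nitrogen on an aromatic ring. Among the measured compounds shown here, no measured step rearranges methoxy groups on one ring; the readable ones swap whole aryl groups. With compound 3 already at the limit, the expected step of a number no higher from compound 3 to compound 4 (the limit leaves the size open) is not resolvable. Compound 4 is therefore expected to read again as a limit, estimated at 50000 nM (range 20000 nM to 120000 nM).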

Compound 4, half-maximal inhibitory concentration: > 50000 nM
Compound 4: a limit, no number (the forecaster's own chance of this, stated with the estimate: 70%); the middle value sits exactly at the limit.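

In this assay, rearranging the methoxy groups from 2,4-dimethoxyphenyl to 3,5-dimethoxyphenyl leaves the series at a limit, so neither arrangement gives a number. The steps from compound 3 and from compound 1 to compound 4 cannot be read: the limit of > 50000 nM in this assay, at which 3 of the 4 values shown sit.

3,5-Dimethoxyphenyl also gives an at least 3.5-fold higher number from compound 2 to compound 4 (0.54 log units; beyond the scatter), so both dimethoxyphenyl arrangements now sit apart from the 4-chlorophenyl group.

Still open, as far as these compounds go, is how far compound 3 and compound 4 differ beyond the limit. Also open, from the compounds shown here alone, is whether a bromophenyl or aminophenyl group on this nitrogen would give a number.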